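The source may hold more compounds than are shown below. What is called first, only, known or untested is meant among the compounds shown, and "the series" means these compounds.

Measured so far:
compound 1, `O=C1NC(=S)S/C1=C\C1=Cc2cc(Br)ccc2OC1`, in a functional assay on A549 cells (Homo sapiens) for antiproliferative activity, read by MTT assay, with a stated time of 72 h (on this read-out lower numbers stand for stronger inhibition and higher numbers for weaker inhibition), gives 51000 nM.
compound 2, `O=C(O)CN1C(=O)/C(=C/C2=Cc3cc(Br)ccc3OC2)SC1=S`, in this assay gives > 25000 nM, which is a limit of the assay and not a number.
compound 3, `CC1Oc2ccc(Br)cc2C=C1/C=C1\SC(=S)NC1=O`, in this assay gives 47500 nM.

Compound 3 thus holds one of only two numbers shown, the third value being a limit. Its nearest neighbour is compound 1, and the gap between them, a 1.1-fold lower number from compound 1 to compound 3 (0.03 log units; within the scatter), is too small to call either one more active than the other.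

The next compound is compound 4, `CC1Oc2ccc(Br)cc2C=C1/C=C1\SC(=S)N(CC(=O)O)C1=O`. It differs from compound 3 by carboxymethyl in place of hydrogen on an amide-type nitrogen in a ring. The same change has been made once before on this core, as the step that the limit leaves unreadable from compound 1 to compound 2. That step cannot be read, since the second value sits at the limit of > 25000 nM in this assay, at which 1 of the 3 values shown sits. So the only precedent for this change gives no direction and no size.

With no readable guide, the expectation for compound 4 is a number close to that of compound 3, the estimated step of a 1.1-fold higher number from compound 3 to compound 4 (0.02 log units; within the scatter) lying within the scatter, though a limit instead of a number is quite possible. Compound 4 is therefore expected to give about 50000 nM in this assay, with a likely range from 20000 nM to 150000 nM.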

Compound 4, half-maximal inhibitory concentration: > 50000 nM
Compound 4 was reported as a limit (the forecaster's own chance of this, stated with the estimate: 40%); the middle value sits exactly at the limit.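

In this assay the step is an at least 1.0-fold higher number from compound 3 to compound 4 (0.02 log units; that floor lies within the scatter), which gives carboxymethyl in place of the amide hydrogen its first readable floor, though that floor shows only the smallest possible size of the step and not its true size. The value of compound 4 is a limit and not a number: the limit of > 50000 nM in this assay, at which 1 of the 4 values shown sits.

Compound 2 also ends at a limit, so on the core with the methyl group and on the core without it, the compound with carboxymethyl on the amide-type nitrogen is reported as a limit, while the partner with the hydrogen gives a number; the steps that involve compound 2 cannot be read.

From the compounds shown here alone, how far the true number of compound 4 lies from that of compound 3 remains open, as does whether the methyl group on the saturated ring carbon makes any difference once carboxymethyl is present. Going by these compounds, it is also open whether a different group on the same nitrogen, such as an ethyl group or a longer chain ending in an amine, would give a readable number in this assay.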